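The source may report more compounds than this note shows. Statements on the series, on what has been measured and on what is new or still open speak of the compounds shown alone.

Two compounds share one core and differ only in the aryl group attached to the sulfonyl sulfur. Compound 1 `Cc1ccccc1S(=O)(=O)Nc1cccc(/C=C/C(=O)c2nc3ccccc3[nH]2)c1` carries a 2-methylphenyl there, and in a functional assay on HCT-116 cells (Homo sapiens) for antiproliferative activity, read by MTT assay, with a stated time of 48 h (on this read-out higher numbers stand for weaker inhibition and lower numbers for stronger inhibition), compound 1 gives 955 nM. Compound 2 `Cc1ccc(S(=O)(=O)Nc2cccc(/C=C/C(=O)c3nc4ccccc4[nH]3)c2)cc1` carries a 4-methylphenyl instead, and in this assay compound 2 gives 1990 nM. Among the measured compounds shown here, the single measured step is a 2.1-fold higher number from compound 1 to compound 2 (0.32 log units; beyond the scatter), so compound 2 stands as the higher of the two numbers, with compound 1 the lower one.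

Compound 3 `Cc1cc(C)cc(S(=O)(=O)Nc2cccc(/C=C/C(=O)c3nc4ccccc4[nH]3)c2)c1` is the next variation: 3,5-dimethylphenyl in place of 4-methylphenyl on a sulfonyl sulfur. For the measured compounds named here, no measured step shows what a second methyl on this ring does; the only step at hand, a 2.1-fold higher number from compound 1 to compound 2 (0.32 log units; beyond the scatter), concerns moving one methyl to a different place on the ring and was modest. That step bears on the new change only loosely, since compound 3 keeps a methyl pattern unlike either compound 1 or compound 2. The expectation is therefore a step from compound 2 to compound 3 in this assay of about a 1.1-fold lower number from compound 2 to compound 3 (0.04 log units; within the scatter), not clearly beyond the scatter in either direction. On that basis compound 3 is estimated at 1800 nM, with a likely range from 700 nM to 4500 nM.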

Compound 3, half-maximal inhibitory concentration: 1220 nM
Compound 3: the middle estimate sits 1.5-fold (0.17 log units) above what was measured; measured number inside the range.
By their numbers in this assay, from the lowest: compounds 1, 3 and 2 (each within the scatter of the next, the first and the last beyond it).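

In this assay, replacing the 4-methylphenyl on the sulfonyl sulfur with a 3,5-dimethylphenyl gives a 1.6-fold lower number from compound 2 to compound 3 (0.21 log units; within the scatter) and replacing the 2-methylphenyl with it gives a 1.3-fold higher number from compound 1 to compound 3 (0.11 log units; within the scatter) so compound 3 cannot be told apart from either one-methyl compound. The earlier pair showed only that the place of a single methyl on this ring can produce a modest step; the new result adds that a ring carrying two methyl groups is accepted here without a step beyond the scatter. Among the compounds shown here, compound 3 therefore does not show a second methyl helping or harming, and only the step between compound 1 and compound 2 remains beyond the scatter, while no measurement at hand explains these numbers.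

As far as these compounds go, all three compounds carry a methyl-substituted phenyl ring on the sulfonyl sulfur, so the effect of a plain phenyl with no methyl at all stays open. Also open, from the compounds shown here alone, is how this position responds to a ring bearing something other than methyl, such as a chlorine, a methoxy group, an amine or a carboxylic acid, or to a longer chain such as ethyl.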